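Cytotoxicity on removal of the arylazo group

A few compounds are considered here, and "the series" means these few. Any claim that something is new, unique, unknown or untested is made for them only; others in the source may bear on it.

Measured compounds, read-out in an ADME assay on MT4 cells (Homo sapiens) for cytotoxicity, read by MTT assay; on this read-out lower numbers stand for higher toxicity in this test and higher numbers for lower toxicity in this test:
- compound 1 `Cc1nc(N2Nc3onc(-c4ccccc4)c3C2c2ccc(Cl)cc2)sc1/N=N/c1ccc(Br)cc1`, this assay: 390 nM
- compound 2 `COc1ccc(/N=N/c2sc(N3Nc4onc(-c5ccccc5)c4C3c3ccc(Cl)cc3)nc2C)cc1`, this assay: 460 nM
- compound 3 `Cc1nc(N2Nc3onc(-c4ccccc4)c3C2c2ccc(Cl)cc2)sc1/N=N/c1ccc([N+](=O)[O-])cc1`, this assay: 280 nM

Compound 3 stands at the lowest of the three numbers, but its gaps to the others are small: a 1.4-fold lower number from compound 1 to compound 3 (0.14 log units; within the scatter) and a 1.6-fold lower number from compound 2 to compound 3 (0.22 log units; within the scatter), both within the scatter, as is a 1.2-fold higher number from compound 1 to compound 2 (0.07 log units; within the scatter). The three measured compounds therefore sit together on this read-out.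

Compound 4 `Cc1csc(N2Nc3onc(-c4ccccc4)c3C2c2ccc(Cl)cc2)n1` differs from compound 3 by a hydrogen atom in place of a group of 11 heavy atoms (6 carbon, 3 nitrogen, 2 oxygen; one six-membered aromatic ring of carbon only), on an aromatic carbon. Among the compounds with values here, none of the measured steps removes this group; they only exchange one substituent on its six-membered ring for another, and every one of those exchanges stayed within the scatter. They thus give no direct guide to the size or direction of the present step, and the expectation for compound 4 rests on the shared core alone, with wide uncertainty. The working estimate is that the step from compound 3 to compound 4 is expected to be a 2.5-fold higher number from compound 3 to compound 4 (0.40 log units; beyond the scatter), and for compound 4 a value of 700 nM is expected, within a range from 200 nM to 3000 nM.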

Compound 4, half-maximal cytotoxic concentration: 230 nM
Beside the measured number, compound 4's estimate is 3.0-fold (0.48 log units) above it; the range from low to high includes it.
By their numbers in this assay, from the lowest: compounds 4, 3, 1 and 2 (each within the scatter of the next).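

In this assay, a hydrogen atom in place of the whole large group on the aromatic carbon next to the ring sulfur stays within the scatter from all three compounds that carry it (a 1.2-fold lower number from compound 3 to compound 4 (0.09 log units; within the scatter); a 2.0-fold lower number from compound 2 to compound 4 (0.30 log units; within the scatter); a 1.7-fold lower number from compound 1 to compound 4 (0.23 log units; within the scatter)). The earlier exchanges changed only a substituent on that group's six-membered ring, whereas these steps show that, across these four compounds, the read-out holds without the group at all. Nothing available bears on why the number stays put at this position.

Open, going by these compounds, is whether an amine, a carboxylic acid or a longer alkyl chain on this same aromatic carbon would also stay within the scatter. Also open, on these data alone, is what a change at another place on the shared core, such as the chlorine, would do to this read-out.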